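The source may hold more compounds than are shown below. What is called first, only, known or untested is meant among the compounds shown, and "the series" means these compounds.

In a functional assay on FM3A cells (Mus musculus) for antiproliferative activity (on this read-out lower numbers stand for stronger inhibition and higher numbers for weaker inhibition), compound 1 (`COc1cc(C(=O)c2sc(-c3ccccc3)cc2N)cc(OC)c1OC`) gives 13 nM and compound 2 (`COc1cc(C(=O)c2sc(-c3ccc(Cl)c(Cl)c3)cc2N)cc(OC)c1OC`) gives 400 nM while compound 3 (`COc1ccc(-c2cc(N)c(C(=O)c3cc(OC)c(OC)c(OC)c3)s2)cc1`) gives 31 nM as the second highest of the three numbers. Compound 4 (`CCOc1ccc(-c2cc(N)c(C(=O)c3cc(OC)c(OC)c(OC)c3)s2)cc1`) differs from compound 3 by methyl in place of hydrogen on a saturated chain carbon bound to an oxygen on an aromatic ring which turns 4-methoxyphenyl to 4-ethoxyphenyl. Closest in kind is methoxy in place of hydrogen, a modest step with a 2.4-fold higher number from compound 1 to compound 3 (0.38 log units; beyond the scatter) on record. The swaps involving 3,4-dichlorophenyl were large, with a 31-fold higher number from compound 1 to compound 2 (1.49 log units; beyond the scatter) and a 13-fold lower number from compound 2 to compound 3 (1.11 log units; beyond the scatter) on record. None of these steps extends methoxy to ethoxy, so only a small shift or none beyond the scatter is expected in this assay with no firm direction. The estimate for compound 4 is an expected 30 nM (range 11 nM to 85 nM).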

Compound 4, half-maximal inhibitory concentration: 510 nM
Compound 4: the middle estimate sits 17-fold (1.23 log units) below what was measured; the measured number lies above the stated range.
By their numbers in this assay, from the lowest: compound 1; then compound 3; then compounds 2 and 4 (each within the scatter of the next).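

In this assay, the single methyl that turns methoxy into ethoxy gave a 16-fold higher number from compound 3 to compound 4 (1.22 log units; beyond the scatter) and so outweighed the addition of methoxy itself, which gave a 2.4-fold higher number from compound 1 to compound 3 (0.38 log units; beyond the scatter) while ethoxy in place of hydrogen gave a 39-fold higher number from compound 1 to compound 4 (1.59 log units; beyond the scatter) overall. With ethoxy, the 4-substituted phenyl no longer stood apart from 3,4-dichlorophenyl, as a 1.3-fold higher number from compound 2 to compound 4 (0.11 log units; within the scatter) shows, so one carbon at this position separated the two levels seen so far. No evidence at hand accounts for this shift.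

Going by these compounds, whether a longer chain such as propoxy would follow ethoxy remains open. So does what a hydroxy group or an amine would give here.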